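A few compounds are considered here, and "the series" means these few. Any claim that something is new, unique, unknown or untested is made for them only; others in the source may bear on it.

Among the measured compounds shown here, in a toxicity assay on HaCaT cells (Homo sapiens) for cytotoxicity, read by CCK-8 assay, with a stated time of 24 h (a higher number here means that more compound is tolerated, a lower number that less compound is tolerated), compound 1 (`COc1ccccc1Oc1c(N)nc(-c2ccc(C)cc2)nc1Cl`) gives 6300 nM as the only true number so far. Compound 2 (`COc1ccccc1Oc1c(N)nc(-c2cccc(Cl)c2)nc1Cl`) gives > 80000 nM which is a limit of the assay. For the measured compounds named here, the single measured step (an at least 12-fold higher number from compound 1 to compound 2 (1.10 log units; beyond the scatter)) is large, but it lies at another place on the shared core, so it offers only a loose guide to size. Going by the values given here, compound 3 (`COc1ccccc1Oc1c(N)nc(-c2ccc(C)cc2)nc1OCCO`) brings a different change (2-hydroxyethoxy in place of chloro on an aromatic carbon) that no measured step covers. In this assay a moderate rise is expected (a 2.4-fold higher number from compound 1 to compound 3 (0.38 log units; beyond the scatter)) with real uncertainty in its direction. Compound 3 is estimated at 15000 nM (expected range 4000 nM to 60000 nM).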

Compound 3, half-maximal cytotoxic concentration: 56600 nM
The estimate for compound 3 lay 3.8-fold (0.58 log units) below the measured number; measured number inside the range.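

In this assay, 2-hydroxyethoxy in place of chloro gives a 9.0-fold higher number from compound 1 to compound 3 (0.95 log units; beyond the scatter). This shows that the place next to the ring nitrogen, and not only the 4-methylphenyl position changed in the earlier step, can move the number, and that the chloro can be replaced there with more compound tolerated. Compound 2 remains a limit and not a number: the limit of > 80000 nM in this assay, at which 1 of the 3 values shown sits.

This single replacement cannot separate losing the chloro from gaining the 2-hydroxyethoxy group. As far as these compounds go, how a simple amine or a longer chain ending in a carboxylic acid would read at this place stays open.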